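Replacing the alkynyl ether of compound 1 with a methylcyclopentyl ether

The source may hold more compounds than are shown below. What is called first, only, known or untested is meant among the compounds shown, and "the series" means these compounds.

Compound 1 `CC#CCCOc1cccc2ccc(N)nc12` carries a pent-3-yn-1-yl chain on an oxygen on an aromatic ring. In an assay on cells with melanin-concentrating hormone receptor 1 (Homo sapiens) as the target, read by radioligand binding (on this read-out lower numbers stand for stronger inhibition and higher numbers for weaker inhibition), compound 1 reaches only a limit of the assay, > 2000 nM, so no number is known for it. That limit, (the limit of > 2000 nM in this assay, at which 1 of the 2 values shown sits), is all that places compound 1 among the values shown. Compound 2 `Nc1ccc2cccc(OCC3CC4CCC3C4)c2n1` carries another group on the same oxygen, and in this assay compound 2 gives 137 nM. Among the measured compounds shown here, no measured step connects compound 1 and compound 2, so their two values can only be set side by side.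

Compound 3 `CC1CCC(Oc2cccc3ccc(N)nc23)C1` is not yet measured. It differs from compound 1 in one place: 3-methylcyclopentyl in place of pent-3-yn-1-yl on an oxygen on an aromatic ring. The step of an at least 4.0-fold lower number from compound 1 to compound 3 (0.60 log units; beyond the scatter) is expected to be a gain beyond the usual scatter, because compound 2 shows that a group other than the chain on this oxygen can give 137 nM. On that basis compound 3 is estimated at 500 nM in this assay, with a range from 100 nM to 3000 nM.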

Compound 3, half-maximal inhibitory concentration: 823 nM
The estimate for compound 3 lay 1.6-fold (0.22 log units) below the measured number; measured number inside the range.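

Among the compounds shown here, the change gives the first measured one-place comparison at this oxygen: in this assay, 3-methylcyclopentyl in place of pent-3-yn-1-yl gives an at least 2.4-fold lower number from compound 1 to compound 3 (0.38 log units; beyond the scatter). The step shows that swapping this open chain with its triple bond for a five-membered carbon ring, with no hydrogen-bond donor or acceptor added, is enough to bring the read-out from a limit to a real number on the shared core. Compound 1 is known only through a limit, so the step fixes a smallest size and not a true size: the limit of > 2000 nM in this assay, at which 1 of the 3 values shown sits.

The compounds shown leave open whether the gain belongs to the ring itself or to its methyl, as a plain cyclopentyl or a 3-ethylcyclopentyl would be needed to separate the two. They also leave open how a ring carrying a heteroatom, such as a tetrahydrofuranyl or a piperidinyl, or a saturated pentyl chain without the triple bond, would read in this assay on this same oxygen.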